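A few compounds are considered here, and "the series" means these few. Any claim that something is new, unique, unknown or untested is made for them only; others in the source may bear on it.

Measured in a functional assay on the whole organism (strain Sprague-Dawley) for inhibition, with Rattus norvegicus as the target, with a stated time of 10 min; a higher number here means that more compound is needed for the effect, a lower number that less compound is needed:
Compound 1 `O=C(O)c1cnc(-c2ccccc2)[nH]c1=O`: 50 mg/kg
Compound 2 `O=C(O)c1cnc(-c2ccccc2Cl)[nH]c1=O`: 5 mg/kg
Compound 3 `CCCOc1ccccc1-c1ncc(C(=O)O)c(=O)[nH]1`: 0.9 mg/kg

Compound 2, at 5 mg/kg, holds the middle place among these three numbers, with compound 1 higher and compound 3 lower. The next compound to be tested is compound 4 `CCCCOc1ccccc1-c1ncc(C(=O)O)c(=O)[nH]1`, which differs from compound 2 by butoxy in place of chloro on an aromatic carbon.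

Among the compounds with values here, three measured steps bear on this change. Chloro in place of hydrogen gave a 10-fold lower number from compound 1 to compound 2 (1.00 log units; beyond the scatter), and propoxy in place of hydrogen gave a 56-fold lower number from compound 1 to compound 3 (1.74 log units; beyond the scatter). Within the data shown here, the closest precedent is propoxy in place of chloro, which gave a 5.6-fold lower number from compound 2 to compound 3 (0.74 log units; beyond the scatter). Among the measured compounds shown here, no measured compound carries butoxy, so the data do not show how it compares with propoxy.

A modest step to a lower number is therefore expected in this assay, of about the size of the propoxy step. This expectation leans on compound 3 at 0.9 mg/kg, and the uncertainty of moving from propoxy to butoxy widens the range. The estimated change is a 5.0-fold lower number from compound 2 to compound 4 (0.70 log units; beyond the scatter). For compound 4 the expected value is 1 mg/kg, with an estimated range of 0.3 mg/kg to 4 mg/kg.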

Compound 4, dose for 50% inhibition: 0.5 mg/kg
Compound 4: the middle estimate sits 2.0-fold (0.30 log units) above what was measured; the measured number falls inside the stated range.
By their numbers in this assay, from the lowest: compounds 4 and 3 (each within the scatter of the next); then compound 2; then compound 1.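

In this assay, butoxy in place of chloro on an aromatic carbon ortho to a large group gives a 10-fold lower number from compound 2 to compound 4 (1.00 log units; beyond the scatter) and stays beyond the scatter, so propoxy is no longer the only chain shown to improve on chloro here, and butoxy in place of hydrogen gives the widest step in this small set (a 100-fold lower number from compound 1 to compound 4 (2.00 log units; beyond the scatter)). The new information lies in the chain itself: methyl in place of hydrogen on a saturated chain carbon gives a 1.8-fold lower number from compound 3 to compound 4 (0.26 log units; within the scatter) and remains within the scatter, so compound 3 and compound 4 cannot be told apart in this assay, and the added chain carbon shows no effect that can be read. Nothing given here accounts for any of these steps.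

The compounds shown leave open what a longer chain, such as pentoxy or hexyloxy, or a branched one would do on this same aromatic carbon. They also leave open whether an amine or a carboxylic acid at the end of the butoxy chain would be tolerated in this assay as the plain chain is.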